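The source may report more compounds than this note shows. Statements on the series, on what has been measured and on what is new or still open speak of the compounds shown alone.

Three compounds share one core. Compound 1 `Nc1nccn2cc(-c3ccccc3)nc12` carries a free amino group on that core, and in an assay on cells for displacement of a labelled ligand from adenosine receptor A1 (Homo sapiens), read by scintillation counting, with a stated time of 120 min, tested at 1 uM (a lower number here means less inhibition, a higher number more inhibition at the concentration tested (going by the name of the read-out)), compound 1 gives 30%. Compound 2 `O=C(Nc1nccn2cc(-c3ccccc3)nc12)c1ccccc1` bears a benzoyl in place of hydrogen on a nitrogen on an aromatic ring, and in this assay compound 2 gives 18%. Compound 3 `O=C(Nc1nccn2cc(-c3ccccc3)nc12)c1ccco1` bears a (furan-2-yl)carbonyl in place of hydrogen on the same nitrogen, and in this assay compound 3 gives 25%. Compound 3 stands within the scatter of both neighbours: a number 5 percentage points lower from compound 1 to compound 3 (within the scatter), and a number 7 percentage points higher from compound 2 to compound 3 (within the scatter). Among the compounds with values here, the only step beyond the scatter is the acylation itself, a number 12 percentage points lower from compound 1 to compound 2 (beyond the scatter), a modest loss.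

Compound 4 `O=C(Nc1nccn2cc(-c3ccccc3)nc12)c1cccnc1` is the next member. The change is pyridin-3-yl in place of furan-2-yl on a carbonyl carbon. The step that bears on it most directly is the exchange of aryl groups on the carbonyl carbon, a number 7 percentage points higher from compound 2 to compound 3 (within the scatter), which stayed within the scatter; the two acylations, a number 12 percentage points lower from compound 1 to compound 2 (beyond the scatter) and a number 5 percentage points lower from compound 1 to compound 3 (within the scatter), show that a (pyridin-3-yl)carbonyl amide is unlikely to rise above compound 1. Compound 4 is therefore expected to show no step beyond the scatter, with a number 3 percentage points lower from compound 3 to compound 4 (within the scatter) as the estimated shift. The estimate for compound 4 in this assay is 22%, expected to fall between 10% and 34%.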

Compound 4, a percentage reported as inhibition, at one concentration (the size of the read-out at that concentration, not a potency): 24%
Estimate against measurement, compound 4: 2 percentage points below, within the range that was stated.
By their numbers in this assay, from the lowest: compounds 2, 4, 3 and 1 (each within the scatter of the next, the first and the last beyond it).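

In this assay, pyridin-3-yl on the carbonyl carbon, a six-membered aromatic ring in place of the five-membered furan-2-yl, leaves the read-out within the scatter (a number 1 percentage points lower from compound 3 to compound 4 (within the scatter)). The same holds against the phenyl amide (a number 6 percentage points higher from compound 2 to compound 4 (within the scatter)), so phenyl, furan-2-yl and pyridin-3-yl on this carbonyl carbon cannot be told apart here, and the earlier pair of aryl groups now extends to pyridin-3-yl, which carries a ring nitrogen. Compound 4 also stays within the scatter of the free amino compound (a number 6 percentage points lower from compound 1 to compound 4 (within the scatter)), which leaves compound 2 as the only one of the amides with a step from compound 1 beyond the scatter, so acylation as such is not shown to lower the number across the series (no measurement given here accounts for any of these numbers).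

All three acyl groups shown carry an aromatic ring, so it stays open how an acetyl group or a longer alkyl chain on the carbonyl carbon would read in this assay. On these data alone, it also stays open whether an amine or a carboxylic acid on the aryl ring would move the number beyond the scatter of compound 4.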